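A thiazole gives way to a methoxyphenyl group

The source may hold more compounds than are shown below. What is called first, only, known or untested is meant among the compounds shown, and "the series" means these compounds.

Compound 1 `O=C(Nc1ccc(Cl)cc1CN1C(=O)c2ccccc2C1=O)c1ccccc1`: in an assay on CHO cells for positive allosteric modulation of metabotropic glutamate receptor 5 (Rattus norvegicus), read by FLIPR (on this read-out lower numbers stand for an effect already at smaller amounts and higher numbers for an effect only at larger amounts of compound), compound 1 gives < 1000 nM, a limit of the assay.
Compound 2 `O=C(Nc1ccc(Cl)cc1CN1C(=O)c2ccccc2C1=O)c1cncs1`: in this assay compound 2 gives < 1000 nM, likewise a limit of the assay.

Compound 2 stands at a limit on the numbers shown, and the one further value, that of compound 1, is a limit as well. The step that the two limits leave unreadable from compound 1 to compound 2 is not readable from two limits; what the pair shows is summed up by the limit of < 1000 nM in this assay, at which 2 of the 2 values shown sit. Compound 3 `COc1ccccc1C(=O)Nc1ccc(Cl)cc1CN1C(=O)c2ccccc2C1=O` differs from compound 2 by 2-methoxyphenyl in place of 1,3-thiazol-5-yl on a carbonyl carbon. Going by the values given here, no measured step bears on this change with a readable size. Compound 3 is expected to stay near the same limit, with a step that the limit leaves unreadable from compound 2 to compound 3 that is not expected to reach beyond the scatter in either direction. For compound 3 in this assay the estimate is 300 nM, within a range from 40 nM to 2500 nM.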

Compound 3, half-maximal effective concentration: < 1000 nM
Compound 3: only a limit was reported; the forecaster's own chance of this, stated with the estimate: 55%; the middle value is on the limit's open side.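

No step among compound 1, compound 2 and compound 3 can be read, and all that the three share is a limit, not a number: the limit of < 1000 nM in this assay, at which 3 of the 3 values shown sit.

The compounds shown leave open how far apart the three actually lie, and whether 2-methoxyphenyl, 1,3-thiazol-5-yl or phenyl on the carbonyl carbon makes any difference in size.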